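Working notes on the shared core: compound 2 to compound 4

The compounds below may be only part of what the source reports. "The series", "measured", "known", "first", "only" and "open" are said of these compounds alone.

The series shares the core of compound 2 `C=CNCc1cc(-c2c(C(=O)NCC)noc2-c2cc(C(C)C)c(O)cc2O)on1`. Among the compounds with values here, in a functional assay on A2780 cells (Homo sapiens) for inhibition (on this read-out higher numbers stand for weaker inhibition and lower numbers for stronger inhibition), compound 1 `CCNC(=O)c1noc(-c2cc(C(C)C)c(O)cc2O)c1-c1cc(COCC(=O)OC)no1` shows "not determined" (no result reported) and compound 3 `CCNC(=O)c1noc(-c2cc(C(C)C)c(O)cc2O)c1-c1cc(CN2CCN(C)CC2)no1` shows "not determined" (no result reported), so compound 2 holds the only number: in this assay compound 2 gives 43 nM. Within the data shown here, no step between measured compounds can be drawn from these entries.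

Compound 4 `CCNC(=O)c1noc(-c2cc(C(C)C)c(O)cc2O)c1-c1cnn(C(C)C)c1` differs from compound 2 by one change: 1-isopropyl-1H-pyrazol-4-yl in place of 3-((vinylamino)methyl)-1,2-oxazol-5-yl on an aromatic carbon. Among the measured compounds shown here, nothing among the measured entries shows how a change of this kind moves the read-out. The step expected here, a 1.9-fold higher number from compound 2 to compound 4 (0.27 log units; within the scatter), is a modest loss of inhibition, probably near the usual scatter rather than far beyond it. On that basis compound 4 is expected to give 80 nM in this assay, with an estimated range from 25 nM to 300 nM.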

Compound 4, half-maximal inhibitory concentration: 21 nM
Beside the measured number, compound 4's estimate is 3.8-fold (0.58 log units) above it, and the stated range ends above it.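

Within the data shown here, at this position, on an aromatic carbon, 1-isopropyl-1H-pyrazol-4-yl in place of 3-((vinylamino)methyl)-1,2-oxazol-5-yl gives in this assay a 2.0-fold lower number from compound 2 to compound 4 (0.31 log units; beyond the scatter) as the first readable step. The position therefore keeps inhibition with a substituent carrying no hydrogen-bond donor, and the modest gain lies just beyond the scatter. No measurement shown bears on the reason for this result.

This single step cannot separate the contributions of the pyrazole ring and the isopropyl group, and steps involving compound 1 and compound 3 cannot be read. A primary amine or a carboxylic acid on the pyrazole nitrogen remains an open comparison.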